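Putting Aminomethyl Back on Compound 2

A few compounds are considered here, and "the series" means these few. Any claim that something is new, unique, unknown or untested is made for them only; others in the source may bear on it.

In an ADME assay on HeLaP4-2 cells (Homo sapiens) for cytotoxicity, read by resazurin assay (a higher number here means that more compound is tolerated, a lower number that less compound is tolerated), compound 2 (`O=c1cc(-c2cccc(-c3ccccc3)c2)c2cccnc2n1O`) gives > 50000 nM, a limit of the assay and not a number. Compound 1 (`NCc1ccc(-c2cccc(-c3cc(=O)n(O)c4ncccc34)c2)cc1`) gives 2300 nM in this assay. Compound 3 (`NCc1cccc(-c2cccc(-c3cc(=O)n(O)c4ncccc34)c2)c1`) differs from compound 2 by aminomethyl in place of hydrogen on an aromatic carbon. For the measured compounds named here, one measured step bears on this: an at least 21-fold higher number from compound 1 to compound 2 (1.33 log units; beyond the scatter), which is large and lost that same group. A large step in the opposite direction, to a lower number, is therefore expected. The expected step is an at least 16-fold lower number from compound 2 to compound 3 (1.22 log units; beyond the scatter). Compound 3 is estimated at 3000 nM, with an expected range of 900 nM to 12000 nM.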

Compound 3, half-maximal cytotoxic concentration: 4900 nM
Compound 3: middle estimate off by 1.6-fold (0.21 log units), on the low side, within the range that was stated.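

In this assay, aminomethyl in place of hydrogen on the terminal phenyl gives an at least 10-fold lower number from compound 2 to compound 3 (1.00 log units; beyond the scatter) at this new position, so the lower number is not confined to the 4-(aminomethyl)phenyl of compound 1. Setting 3-(aminomethyl)phenyl in place of 4-(aminomethyl)phenyl gives a 2.1-fold higher number from compound 1 to compound 3 (0.33 log units; beyond the scatter) and so shows that the position of the group has a modest bearing on the read-out. As far as these compounds go, compound 2 has a limit of the assay and not a number, so the full size of the first step stays unknown: the limit of > 50000 nM in this assay, at which 1 of the 3 values shown sits.

The compounds shown leave open whether the amine itself is needed, as a hydroxymethyl at this position would test. They also leave open how a longer chain ending in an amine would compare.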